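A few compounds are considered here, and "the series" means these few. Any claim that something is new, unique, unknown or untested is made for them only; others in the source may bear on it.

Measured so far in a functional assay on HeLa cells (Homo sapiens) for inhibition, read by MTT assay; a lower number here means a stronger inhibitor, a higher number a weaker inhibitor: compound 1 `CCCCCCCCn1cc(/C=C/C(=O)c2ccc(NC(=O)CN3CCN(c4ccccc4)CC3)cc2)nn1` gives 33800 nM; compound 2 `O=C(CN1CCN(c2ccccc2)CC1)Nc1ccc(C(=O)/C=C/c2cn(Cc3ccc(Br)cc3)nn2)cc1` gives 79700 nM; compound 3 `CCCCCCCCn1cc(/C=C/C(=O)c2ccc(NC(=O)CBr)cc2)nn1` gives 8420 nM.

Compound 1 stands second highest of the three numbers. Its nearest neighbour is compound 2, reached by a 2.4-fold higher number from compound 1 to compound 2 (0.37 log units; beyond the scatter); its furthest is compound 3, reached by a 4.0-fold lower number from compound 1 to compound 3 (0.60 log units; beyond the scatter). The step to compound 4 `CCCCCCCCn1cc(/C=C/C(=O)c2ccc(NC(=O)CN3CCN(c4ccccc4OC)CC3)cc2)nn1` keeps the heptyl chain and the whole phenylpiperazine acetamide and changes only the phenyl on the piperazine: methoxy in place of hydrogen on an aromatic carbon. Among the measured compounds shown here, no measured step touches that ring. The nearest comparison is the change in compound 3, which removes the phenylpiperazine and lowers the number; a methoxy added to the phenyl is a far smaller alteration, so in this assay compound 4 is expected to stay close to compound 1, with a 1.1-fold lower number from compound 1 to compound 4 (0.05 log units; within the scatter) not clearly beyond the scatter. Compound 4 is thus estimated at 30000 nM, within 12000 nM to 80000 nM.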

Compound 4, half-maximal inhibitory concentration: 26800 nM
Beside the measured number, compound 4's estimate is 1.1-fold (0.05 log units) above it; low and high end bracket the measured number.
By their numbers in this assay, from the lowest: compound 3; then compounds 4 and 1 (each within the scatter of the next); then compound 2.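

Methoxy in place of hydrogen on the phenyl, ortho to a large group, gives a 1.3-fold lower number from compound 1 to compound 4 (0.10 log units; within the scatter) in this assay and is the first measured change on that ring. Unlike the earlier steps, which replaced the heptyl or the whole 4-phenylpiperazin-1-yl and moved the number beyond the scatter, this one leaves compound 4 and compound 1 indistinguishable. No measurement at hand bears on why.

Going by these compounds, whether a larger ring substituent, such as a trifluoromethyl or a carboxylic acid, would shift the number stays open. So does the outcome of methoxy elsewhere on the phenyl.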